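The source may hold more compounds than are shown below. What is called first, only, known or untested is meant among the compounds shown, and "the series" means these compounds.

Measured compounds:
- compound 1, `Oc1cccc(-c2cc(-c3ccncc3)nc(-c3ccccc3Cl)c2)c1`: "not determined" (no result reported)
- compound 2, `Oc1ccc(-c2cc(-c3cccs3)nc(-c3ccccc3Cl)c2)cc1`: 4190 nM

In a functional assay on DU-145 cells (Homo sapiens) for cytotoxicity, read by CCK-8 assay and cell counting, with a stated time of 2 days (a higher number here means a weaker inhibitor, a lower number a stronger inhibitor), compound 1 has no single number; it stands nowhere on the scale, and only compound 2 carries a value there. Compound 2 differs from compound 1 in more than one place, so its value shows only the range the series has reached so far. Compound 3, `Oc1cccc(-c2cc(-c3ccsc3)nc(-c3ccccc3Cl)c2)c1`, follows compound 1 by one change: thiophen-3-yl in place of pyridin-4-yl on an aromatic carbon. With no number for compound 1, no size or direction for this step in this assay can be set from the data; the step may be no larger than the scatter, but nothing shown decides it. For the measured compounds named here, the only anchor is compound 2 in this assay at 4190 nM, and compound 3 is expected to fall in a similar region. For compound 3 in this assay the estimate is 4000 nM, with a range from 1000 nM to 15000 nM.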

Compound 3, half-maximal inhibitory concentration: 1970 nM
Estimate against measurement, compound 3: 2.0-fold (0.31 log units) above; low and high end bracket the measured number.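

No step can be read between compound 1 and compound 3 in this assay, where compound 3 gives 1970 nM and compound 1 shows no single number. The compounds shown leave open how thiophen-3-yl compares with pyridin-4-yl on the shared core. Nothing available bears on the result.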